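A few compounds are considered here, and "the series" means these few. Any claim that something is new, unique, unknown or untested is made for them only; others in the source may bear on it.

Compound 1 `N[C@H](C(=O)O)[C@@H]1CC(Br)=NO1` is the starting point of this short series. Among the measured compounds shown here, in an ADME assay on HMEC-1 cells (Homo sapiens) for cytotoxicity, read by MTT assay, with a stated time of 72 h (a higher number here means a weaker inhibitor, a lower number a stronger inhibitor), compound 1 gives 19700 nM, the only number available here, so it stands alone with nothing to compare against. Compound 2 `COc1ccc(CNC(=O)[C@@H](N)[C@@H]2CC(Br)=NO2)cc1` belongs to the same set, yet in this assay compound 2 gives "not determined" (no result reported). Compound 3 `COC(=O)[C@@H](N)[C@@H]1CC(Br)=NO1` differs from compound 1 by methyl in place of hydrogen on an oxygen next to a carbonyl group, that is, carboxy to methoxycarbonyl. For the measured compounds named here, no measured pair shows what such a change does. Compound 3 is expected to shift only a little toward stronger inhibition, a step of a 1.6-fold lower number from compound 1 to compound 3 (0.22 log units; within the scatter), within the usual scatter. Compound 3 is therefore estimated at 12000 nM, with a range from 4000 nM to 40000 nM.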

Compound 3, half-maximal inhibitory concentration: 34800 nM
Compound 3: the middle estimate sits 2.9-fold (0.46 log units) below what was measured; low and high end bracket the measured number.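

Methyl in place of hydrogen on an oxygen next to a carbonyl group, carboxy to methoxycarbonyl, gives a 1.8-fold higher number from compound 1 to compound 3 (0.25 log units; within the scatter) in this assay. This first measured step at this position shows that compound 1 and compound 3 cannot be told apart in this assay, so this small change leaves the reading within the usual scatter. No supporting measurement bears on this result.

Among the compounds shown here, compound 2 has no number, so no step to it can be read. Going by these compounds, whether a longer chain such as ethyl, or a benzyl group, on the same oxygen would give a clearer difference stays open.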